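Swapping the Amide Arm for a Benzyl Carbamate

The source may report more compounds than this note shows. Statements on the series, on what has been measured and on what is new or still open speak of the compounds shown alone.

Compound 1 `CNC(=O)c1cc(C)n(Cc2cc(Cl)ccc2OCc2ccccc2)n1`: 100 nM
Compound 2 `Cc1cc(C(=O)Nc2cccc(F)c2)nn1Cc1cc(Cl)ccc1OCc1ccccc1`: 200 nM
Compound 3 `CC(=O)Nc1cc(C)n(Cc2cc(Cl)ccc2OCc2ccccc2)n1`: 316 nM

All three were measured in an assay on CHO-K1 cells for displacement of a labelled ligand from prostaglandin E2 receptor EP1 subtype (Homo sapiens); on this read-out higher numbers stand for weaker inhibition and lower numbers for stronger inhibition. Compound 2 stands second highest of the three numbers; its nearest neighbour is compound 3, with a 1.6-fold higher number from compound 2 to compound 3 (0.20 log units; within the scatter), and its furthest is compound 1, with a 2.0-fold higher number from compound 1 to compound 2 (0.30 log units; within the scatter), so both neighbours sit within the scatter of compound 2.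

Compound 4 `Cc1cc(NC(=O)OCc2ccccc2)nn1Cc1cc(Cl)ccc1OCc1ccccc1` has not yet been measured. It differs from compound 2 in one place: (benzyloxycarbonyl)amino in place of (3-fluorophenyl)carbamoyl on an aromatic carbon.

Among the compounds with values here, two measured steps bear on this change. Replacing the methylcarbamoyl of compound 1 by acetamido, a group joined through an amino nitrogen as (benzyloxycarbonyl)amino is, gave a 3.2-fold higher number from compound 1 to compound 3 (0.50 log units; beyond the scatter). Replacing the (3-fluorophenyl)carbamoyl of compound 2 by acetamido gave a 1.6-fold higher number from compound 2 to compound 3 (0.20 log units; within the scatter). Both point the same way, toward somewhat weaker inhibition, but neither is large, and the first step, from methyl to 3-fluorophenyl on the amide-type nitrogen, a 2.0-fold higher number from compound 1 to compound 2 (0.30 log units; within the scatter), shows that a larger aromatic group on this arm changes little.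

A modest weakening at most is therefore expected, a 1.6-fold higher number from compound 2 to compound 4 (0.20 log units; within the scatter). Compound 4 is estimated at 320 nM, with a likely range from 120 nM to 900 nM.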

Compound 4, half-maximal inhibitory concentration: 79.4 nM
Compound 4: middle estimate off by 4.0-fold (0.61 log units), on the high side; the whole stated range lies above it.
By their numbers in this assay, from the lowest: compounds 4, 1, 2 and 3 (each within the scatter of the next, the first and the last beyond it).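

Compound 3 and compound 4 both reach the shared core through an amino nitrogen, yet benzyloxy in place of methyl on the carbonyl carbon gives a 4.0-fold lower number from compound 3 to compound 4 (0.60 log units; beyond the scatter) in this assay, so on this arm the attachment through nitrogen does not by itself set the number, and the group beyond the carbonyl also counts. The amino-linked arm also carries no general penalty, as (benzyloxycarbonyl)amino in place of (3-fluorophenyl)carbamoyl gives a 2.5-fold lower number from compound 2 to compound 4 (0.40 log units; beyond the scatter) and the same arm in place of methylcarbamoyl gives a 1.3-fold lower number from compound 1 to compound 4 (0.10 log units; within the scatter), which leaves that pair indistinguishable in this assay. Nothing shown here accounts for these steps.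

As far as these compounds go, what remains open is whether the gain over compound 3 comes from the benzyl ring, the carbamate oxygen or both, a question that a methyl carbamate, a phenylacetamide or a benzyl urea on the same ring carbon could help to separate. From the compounds shown here alone, it is also open whether the benzyl ring of this arm tolerates further groups, such as a fluorine or a methoxy group, and how such a change would compare with compound 4.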